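Notes on a platelet inhibition series, compounds 1 to 3

The compounds below may be only part of what the source reports. "The series", "measured", "known", "first", "only" and "open" are said of these compounds alone.

Measured compounds:
compound 1, `N#Cc1cc2c(nc1N1CCC(C(=O)NS(=O)(=O)C(F)(F)c3ccccc3)CC1)COC2=O`: "not determined" (no result reported) in a functional assay (Platelet, plasma) for inhibition, with Homo sapiens as the target; a lower number here means a stronger inhibitor, a higher number a weaker inhibitor
compound 2, `CC(c1ccccc1)S(=O)(=O)NC(=O)C1(F)CCN(c2nc3c(cc2C#N)C(=O)OC3)CC1`: 9950 nM in this assay

Compound 1 has no number in this assay; its standing in the series cannot be placed. Going by the values given here, the only measured value belongs to compound 2, which in this assay gives 9950 nM, a weak result. Compound 3, `N#Cc1ccc(CS(=O)(=O)NC(=O)C2CCN(c3nc4c(cc3C#N)C(=O)OC4)CC2)cc1`, is the next compound to be measured. It differs from compound 1 by 4-cyanobenzyl in place of difluoro(phenyl)methyl on a sulfonyl sulfur. Among the compounds with values here, no step between measured compounds is known, so the size of the change from compound 1 to compound 3 in this assay cannot be read from the data; no direction is expected with confidence, and a step within the scatter is as plausible as one beyond it. Compound 3 is estimated at 8000 nM, in a range from 1500 nM to 40000 nM, since compound 2 gives 9950 nM.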

Compound 3, half-maximal inhibitory concentration: 8900 nM
For compound 3 the middle estimate is 1.1-fold (0.05 log units) below the measured one; low and high end bracket the measured number.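

Going by these compounds alone, compound 1 has no number in this assay, so no step to compound 3 at 8900 nM can be read. The compounds shown leave open what 4-cyanobenzyl in place of difluoro(phenyl)methyl does in this assay and no evidence bears on this result.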